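Acetamido-to-amino step on the shared core, cytotoxicity

This account rests on a few compounds, and the source may have more. Where it says the series, first, only, none or still open, it means among the compounds named here.

Compound 1 `COc1ccccc1-c1cc(=O)c2cc(NC(C)=O)ccc2o1` and compound 2 `COc1ccc(-c2cc(=O)c3cc(NC(C)=O)ccc3o2)cc1` carry the same atoms joined differently; the difference between the two cores is not broken down here. In an ADME assay on MT4 cells (Homo sapiens) for cytotoxicity, read by MTT assay, with a stated time of 4 days (on this read-out lower numbers stand for higher toxicity in this test and higher numbers for lower toxicity in this test), compound 1 gives 226000 nM, and compound 2 gives 226000 nM, the two numbers agreeing at the digits given. Compound 3 `COc1ccccc1-c1cc(=O)c2cc(N)ccc2o1` is compound 1 after the change (hydrogen in place of acetyl on a nitrogen on an aromatic ring), and in this assay compound 3 gives 198000 nM; the step of a 1.1-fold lower number from compound 1 to compound 3 (0.06 log units; within the scatter) is small. Compound 4 `COc1ccc(-c2cc(=O)c3cc(N)ccc3o2)cc1` is compound 2 after the change (hydrogen in place of acetyl on a nitrogen on an aromatic ring), the same change made on the core of compound 2, at a place described in the same words as for compound 3. Within the data shown here, only one measured instance of the change exists, that from compound 1 to compound 3. Among the measured compounds shown here, the step of a 1.1-fold lower number from compound 2 to compound 4 (0.05 log units; within the scatter) is expected to be about as small, resting on a 1.1-fold lower number from compound 1 to compound 3 (0.06 log units; within the scatter) alone, since no second measured pair is available. In this assay compound 4 is therefore estimated at 200000 nM, expected to fall between 120000 nM and 330000 nM.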

Compound 4, half-maximal cytotoxic concentration: 241000 nM
Compound 4: the middle estimate sits 1.2-fold (0.08 log units) below what was measured; measured number inside the range.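

In this assay, the acetamido to amino change on the core of compound 2 gives a small step, a 1.1-fold higher number from compound 2 to compound 4 (0.03 log units; within the scatter), and the two instances of the change agree: the same change on two cores in this assay, a 1.1-fold lower number (0.06 log units; within the scatter) from compound 1 to compound 3 and a 1.1-fold higher number (0.03 log units; within the scatter) from compound 2 to compound 4, 1.2-fold (0.09 log units) apart, within the scatter of two such steps

Across these two pairs, the change therefore carries from the core of compound 1 to the core of compound 2 with no step beyond the scatter on either core. Neither step can be given a direction, and two pairs set no rule for other cores or for any other read-out.

The compounds shown leave open whether a longer acyl chain, a sulfonamide or a dialkylamine on that nitrogen would stay within the scatter of the acetamido and amino compounds in this assay. Also open, on these data alone, is whether a hydroxyl group or a fluorine atom in place of the methoxy group would give a step beyond the scatter on either core.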